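A few compounds are considered here, and "the series" means these few. Any claim that something is new, unique, unknown or untested is made for them only; others in the source may bear on it.

Compound 1 `O=C(Nc1cccc(-n2cc(-c3ccncc3)c(-c3cc(O)cc(Cl)c3)n2)c1)Nc1ccc(Cl)c(C(F)(F)F)c1` gives 2100 nM in a functional assay on UO-31 cells (Homo sapiens) for inhibition, read by sulforhodamine B assay, with a stated time of 48 h (on this read-out higher numbers stand for weaker inhibition and lower numbers for stronger inhibition), standing at the top of the two numbers shown, with the gap to compound 2 inside the scatter. Compound 2 `O=C(Nc1cccc(-n2cc(-c3ccncc3)c(-c3cc(O)cc(Cl)c3)n2)c1)Nc1ccc(Cl)c(Cl)c1` gives 1910 nM in this assay; the step of a 1.1-fold lower number from compound 1 to compound 2 (0.04 log units; within the scatter) changes the urea end only. Compound 3 `COc1cc(Cl)cc(-c2nn(-c3cccc(NC(=O)Nc4ccc(Cl)c(C(F)(F)F)c4)c3)cc2-c2ccncc2)c1` differs from compound 1 by methyl in place of hydrogen on an oxygen on an aromatic ring, hydroxy to methoxy on the 3-chloro-5-hydroxyphenyl ring. Among the compounds with values here, no measured step touches this oxygen, so nothing bears on it directly, and no step beyond the scatter is expected in this assay. For compound 3 the expected value is 2500 nM, with a range from 900 nM to 7000 nM. The step of a 1.2-fold higher number from compound 1 to compound 3 (0.08 log units; within the scatter) is thus the estimate.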

Compound 3, half-maximal inhibitory concentration: 1660 nM
Compound 3: the middle estimate sits 1.5-fold (0.18 log units) above what was measured, within the range that was stated.
By their numbers in this assay, from the lowest: compounds 3, 2 and 1 (each within the scatter of the next).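

Methyl in place of hydrogen on this oxygen is the first measured change at this position, and in this assay the step of a 1.3-fold lower number from compound 1 to compound 3 (0.10 log units; within the scatter) lies within the scatter. Hydroxy and methoxy on this ring are therefore not told apart by this read-out, at least with the urea end of compound 1. No measurement at hand gives a reason for this.

Still open, from the compounds shown here alone, is whether a longer chain on this oxygen, such as ethoxy, or an amine in place of the hydroxy would also stay within the scatter. Also open, going by these compounds, is whether methoxy behaves alike with the urea end of compound 2.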